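Swapping a Methoxybenzyl Arm for a Phenoxymethyl Arm

The compounds below may be only part of what the source reports. "The series", "measured", "known", "first", "only" and "open" are said of these compounds alone.

Compound 1, `COc1cccc(CC2CCCCN2C(=O)n2ncc(C(O)(c3ccc(F)cc3)c3ccc(F)cc3)n2)c1`: 3.16 nM
Compound 2, `O=C(N1CCCCC1Cc1ccccc1)n1ncc(C(O)(c2ccccn2)c2ccccn2)n1`: 158 nM
Compound 3, `O=C(N1CCCCC1COc1ccc(F)cc1)n1ncc(C(O)(c2ccccc2)c2ccccc2)n1`: 6.31 nM

Of the compounds shown here, three have been measured in an assay on HEK-293T cells for inhibition of diacylglycerol lipase-alpha (Homo sapiens), read by colorimetric assay; a lower number here means a stronger inhibitor, a higher number a weaker inhibitor. Compound 1 has the lowest number of the three; its gap to compound 3 lies within the usual scatter, while compound 2 stands far beyond it. Compound 4, `O=C(N1CCCCC1COc1ccccc1)n1ncc(C(O)(c2ccc(F)cc2)c2ccc(F)cc2)n1`, differs from compound 1 in one place: phenoxy in place of 3-methoxyphenyl on a saturated chain carbon bound to a saturated ring carbon. The phenoxymethyl arm of compound 3 resembles what enters compound 4. In this assay compound 3 gives 6.31 nM, a number within the scatter of compound 1. The expected step is therefore small, not clearly beyond the scatter, in either direction. Compound 4 is expected to give 5 nM, within 1.5 nM to 16 nM. The estimated step of a 1.6-fold higher number from compound 1 to compound 4 (0.20 log units; within the scatter) is expected to stay inside the usual scatter.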

Compound 4, half-maximal inhibitory concentration: 5.01 nM
Compound 4: middle estimate off by 1.0-fold (0.00 log units), on the low side; the range from low to high includes it.
By their numbers in this assay, from the lowest: compounds 1, 4 and 3 (each within the scatter of the next); then compound 2.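

With everything else held the same, exchanging the 3-methoxybenzyl arm for phenoxymethyl gives a 1.6-fold higher number from compound 1 to compound 4 (0.20 log units; within the scatter) in this assay, so this change leaves the number within the scatter. Compound 3 could not show this, since it differs from compound 1 in more than one place. No evidence is available on why the two arms read alike.

On these data alone, whether an arm ending in an amine or a carboxylic acid, or a longer chain, would also stay within the scatter remains open. The much higher number of compound 2 also remains unassigned to any single change.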